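A few compounds are considered here, and "the series" means these few. Any claim that something is new, unique, unknown or untested is made for them only; others in the source may bear on it.

Measured so far:
compound 1, `CCCn1ccc2c(OCCc3ccc(OC)cc3)cccc2c1=O`: 251 nM
compound 2, `CCCn1ccc2c(NCCCc3ccccc3)cccc2c1=O`: 158 nM

In a functional assay on CHO cells for positive allosteric modulation of metabotropic glutamate receptor 2 (Homo sapiens), read by scintillation counting and GTPgammaS binding, with a stated time of 30 min (a higher number here means that more compound is needed for the effect, a lower number that less compound is needed), compound 2 gives 158 nM, the lower of the two numbers recorded. Compound 1 gives 251 nM in this assay, and the gap between compound 1 and compound 2 lies within the usual scatter, so no order between them is claimed. Compound 3, `CCCn1ccc2c(NCc3ccccc3)cccc2c1=O`, has not yet been measured. It differs from compound 2 in one place: phenyl in place of phenethyl on a saturated chain carbon bound to a nitrogen on an aromatic ring. Among the measured compounds shown here, no pair of measured compounds differing in a single place is available, so the size of such a change cannot be read from the data. Both measured compounds carry a longer link than phenyl to the aromatic ring, so compound 3 is expected to need a moderately higher concentration in this assay, a step beyond the scatter but not a large one. Compound 3 is expected to give 500 nM, in a range from 150 nM to 2000 nM. The expected step is a 3.2-fold higher number from compound 2 to compound 3 (0.50 log units; beyond the scatter).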

Compound 3, half-maximal effective concentration: 2000 nM
For compound 3 the middle estimate is 4.0-fold (0.60 log units) below the measured one; measured number inside the range.
By their numbers in this assay, from the lowest: compounds 2 and 1 (each within the scatter of the next); then compound 3.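

In this assay the series gains its first single-place comparison: phenyl in place of phenethyl on a saturated chain carbon bound to a nitrogen on an aromatic ring gives a 13-fold higher number from compound 2 to compound 3 (1.10 log units; beyond the scatter) as a large step. This position is therefore sensitive to a change that keeps the six-membered aromatic ring of carbon only and adds no hydrogen-bond donor or acceptor; the leaving and entering groups differ in the carbons that link that ring to the chain. No measurement on hand accounts for the size of this step.

As far as these compounds go, whether a longer chain than phenethyl at this position would lower or raise the number remains open. Also open, from the compounds shown here alone, is how an amine or a carboxylic acid on the terminal ring would fare, and whether the same shortening would have a similar effect in compound 1.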